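Propyl to isopropyl on a thioester carbonyl

The compounds below may be only part of what the source reports. "The series", "measured", "known", "first", "only" and "open" are said of these compounds alone.

Three compounds share an amide-linked six-carbon chain ending in sulfur. Compound 1, `C=CCOC(=O)SCCCCCCNC(=O)c1cc(-c2ccncc2)n[nH]1`, carries an allyloxy group on the thioester carbonyl carbon and gives 12600 nM in a functional assay on MCF7 cells (Homo sapiens) for inhibition, read by MTT assay, with a stated time of 96 h; a higher number here means a weaker inhibitor of growth, a lower number a stronger inhibitor of growth. Compound 2, `CCCC(=O)SCCCCCCNC(=O)c1cc(-c2ccncc2)n[nH]1`, carries propyl there instead and gives 12100 nM in this assay. Compound 3, `Cc1cc(C(=O)NCCCCCCS)[nH]n1`, has a free thiol and a different core, and in this assay compound 3 gives > 50000 nM, which is a limit of the measurement rather than a number. That result is the limit of > 50000 nM in this assay, at which 1 of the 3 values shown sits. Going by the values given here, the only measured step, a 1.0-fold lower number from compound 1 to compound 2 (0.02 log units; within the scatter), lies within the scatter. Compound 2 has the lowest of the two numbers reported, yet its gap to compound 1 is within the scatter, so no order between them can be claimed.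

Compound 4, `CC(C)C(=O)SCCCCCCNC(=O)c1cc(-c2ccncc2)n[nH]1`, differs from compound 2 by isopropyl in place of propyl on a carbonyl carbon. Among the compounds with values here, the one measured step at this carbonyl carbon, from an allyloxy group to propyl, gave no shift beyond the scatter, and the present change rearranges the same atoms, so for compound 4 no step beyond the scatter is expected in this assay: the expected step is a 1.0-fold higher number from compound 2 to compound 4 (0.01 log units; within the scatter). Compound 4 is therefore estimated at 12500 nM, with a range from 5000 nM to 32000 nM.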

Compound 4, concentration for 50% growth inhibition: 15200 nM
Compound 4: the middle estimate sits 1.2-fold (0.08 log units) below what was measured, and the stated range covers the measured number.
By their numbers in this assay, from the lowest: compounds 2, 1 and 4 (each within the scatter of the next). At a limit, above all of these: compound 3.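

Isopropyl in place of propyl on the carbonyl carbon rearranges the same atoms, and in this assay there is a 1.3-fold higher number from compound 2 to compound 4 (0.10 log units; within the scatter). Isopropyl in place of allyloxy reads the same way, with a 1.2-fold higher number from compound 1 to compound 4 (0.08 log units; within the scatter), so all three groups tried on this carbonyl carbon now sit within the scatter of one another. Nothing measured here speaks to why these groups read alike.

As far as these compounds go, whether a group of another kind on this carbonyl carbon, such as an amine, a carboxylic acid or a much longer chain, would give a step beyond the scatter remains open. From the compounds shown here alone, compound 3 gives > 50000 nM, which is a limit and not a number, and it differs from the others in more than one place, so the part played by the carbonyl group on sulfur also stays open.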